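The compounds below may be only part of what the source reports. "The series", "measured", "known", "first", "only" and "open" are said of these compounds alone.

Measured compounds:
compound 1 `O=C(/C=C(O)/C=C/c1ccc(O)cc1O)c1ccccc1O`: 61.2%
compound 2 `O=C1/C(=C/c2ccccc2)CCC/C1=C\c1ccc(Br)cc1`: 29.1%

Both were tested in an assay on isolated protein for inhibition of Alpha glucosidase (Homo sapiens), with stated times of 5 min and 15 min, tested at 50 uM; a lower number here means less inhibition, a higher number more inhibition at the concentration tested (going by the name of the read-out). Compound 1 gives 61.2% and compound 2 gives 29.1%, so compound 2 has the lower of the two numbers, and the gap to compound 1 lies beyond the usual scatter. Compound 3 `O=C1/C(=C/c2ccccc2)CCC/C1=C\c1cccc(Br)c1` has not yet been measured. It differs from compound 2 by 3-bromophenyl in place of 4-bromophenyl on a double-bonded chain carbon bound to a double-bonded ring carbon; the two have the same atoms, joined differently. For the measured compounds named here, no measured pair shows what such a move does, so no step beyond the scatter is expected in either direction in this assay. Compound 3 is therefore expected to give about 30%, between 15% and 45%, an expected step of a number 0.9 percentage points higher from compound 2 to compound 3 (within the scatter) that stays within the scatter.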

Compound 3, a percentage reported as inhibition, at one concentration (the size of the read-out at that concentration, not a potency): 27.2%
Compound 3: middle estimate off by 2.8 percentage points, on the high side; low and high end bracket the measured number.
By their numbers in this assay, from the lowest: compounds 3 and 2 (each within the scatter of the next); then compound 1.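

In this assay, putting 3-bromophenyl in place of 4-bromophenyl on a double-bonded chain carbon bound to a double-bonded ring carbon gives a number 1.9 percentage points lower from compound 2 to compound 3 (within the scatter). For the compounds shown here, this is the first pair that differs in one place, and this read-out at this concentration does not separate the two bromophenyl groups. Nothing available here accounts for this result.

On these data alone, whether an amine or a carboxylic acid in place of the bromine would give a step beyond the scatter stays open. As far as these compounds go, compound 1 differs from both in more than one place, so what sets it apart also stays open.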